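The source may hold more compounds than are shown below. What is called first, only, known or untested is meant among the compounds shown, and "the series" means these compounds.

Compound 3, `CCOC(=O)c1cnc(N2CCN(Cc3ccccc3[N+](=O)[O-])CC2)nc1Oc1c(C)cc(-c2ccc(C#N)cc2)cc1C`, is one of three close analogues on a shared core that were tested in an ADME assay on MT4 cells (Homo sapiens) for cytotoxicity, read by MTT assay, with a stated time of 4 days; on this read-out higher numbers stand for lower toxicity in this test and lower numbers for higher toxicity in this test. For compound 3 the result is only a limit, >= 78700 nM. Compound 1, `CCOC(=O)c1cnc(N2CCN(Cc3ccc(F)cc3)CC2)nc1Oc1c(C)cc(-c2ccc(C#N)cc2)cc1C`, likewise gives only a limit in this assay, > 117000 nM. Compound 2, `CCOC(=O)c1cnc(N2CCN(Cc3cccc([N+](=O)[O-])c3)CC2)nc1Oc1c(C)cc(-c2ccc(C#N)cc2)cc1C`, also gives only a limit in this assay, > 125000 nM. The steps among them, a step that the two limits leave unreadable from compound 1 to compound 2, a step that the two limits leave unreadable from compound 1 to compound 3 and a step that the two limits leave unreadable from compound 2 to compound 3, therefore cannot be sized: each value sits at a limit, as the limit of > 117000 nM in this assay, at which 1 of the 3 values shown sits, the limit of > 125000 nM in this assay, at which 1 of the 3 values shown sits, and the limit of >= 78700 nM in this assay, at which 1 of the 3 values shown sits, show. Compound 4, `CCOC(=O)c1cnc(N2CCN(Cc3cccc(C(N)=O)c3)CC2)nc1Oc1c(C)cc(-c2ccc(C#N)cc2)cc1C`, differs from compound 3 by 3-carbamoylphenyl in place of 2-nitrophenyl on a saturated chain carbon bound to an amine nitrogen in a ring. Every measured exchange of the group on the saturated chain carbon bound to an amine nitrogen in a ring left the read-out at a limit, and the same outcome is expected for compound 4, so that a step that the limit leaves unreadable from compound 3 to compound 4 is expected to stay within the scatter. Compound 4 is expected at 110000 nM, with a range from 50000 nM to 250000 nM, most likely again reported as a limit.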

Compound 4, half-maximal cytotoxic concentration: 14800 nM
The estimate for compound 4 lay 7.4-fold (0.87 log units) above the measured number, outside the stated range (below it).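

Among the compounds shown here, compound 4 gives the first value in this set that is not a limit, showing that the group on a saturated chain carbon bound to an amine nitrogen in a ring can move the read-out in this assay toward higher toxicity in this test. The cleanest comparison is an at least 8.4-fold lower number from compound 2 to compound 4 (0.92 log units; beyond the scatter), where only carbamoyl replaces nitro on an aromatic carbon, while an at least 5.3-fold lower number from compound 3 to compound 4 (0.72 log units; beyond the scatter) and an at least 7.9-fold lower number from compound 1 to compound 4 (0.89 log units; beyond the scatter) run the same way, and each of the three gives only a minimum size. Nothing measured here explains the shift.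

On these data alone, it remains open whether a carboxylic acid or an amine in place of carbamoyl on that aromatic carbon would lower the number as well. Also open, as far as these compounds go, is how far compound 1, compound 2 and compound 3 lie beyond their limits, so the true size of each step is unknown.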